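The compounds below may be only part of what the source reports. "The series", "measured", "known", "first", "only" and "open" are said of these compounds alone.

The measured compounds:

Compound 1, `CC(C)(C)c1cc(NC(=O)Nc2ccc(-c3cn4ccccc4n3)cc2)no1`, gives 3.09 nM in a functional assay on MV4-11 cells (Homo sapiens) for cytotoxicity, read by MTT assay, with a stated time of 72 h; a higher number here means a weaker inhibitor, a lower number a stronger inhibitor.
Compound 2, `CC(C)(C)c1cc(NC(=O)Nc2ccc(-c3cn4cccc(F)c4n3)cc2)no1`, gives 12.2 nM.
Compound 3, `CC(C)(C)c1cc(NC(=O)Nc2ccc(-c3cn4cccc(C(F)(F)F)c4n3)cc2)no1`, gives > 900 nM; this value is a limit of this assay, not a number (the limit of > 900 nM in this assay, at which 1 of the 3 values shown sits).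

Compound 1 thus gives the lowest of the numbers shown. Compound 4, `CC(C)(C)c1cc(NC(=O)Nc2ccc(-c3cn4ccc(Br)cc4n3)cc2)no1`, differs from it by bromo in place of hydrogen on an aromatic carbon. The bromo does not sit at the place of the fluoro or trifluoromethyl of compounds 2 and 3, so the measured steps bear on it only loosely. Both were weakening: a 3.9-fold higher number from compound 1 to compound 2 (0.60 log units; beyond the scatter) was modest, an at least 290-fold higher number from compound 1 to compound 3 (2.46 log units; beyond the scatter) large, and an at least 73-fold higher number from compound 2 to compound 3 (1.86 log units; beyond the scatter) large too. A modest weakening, a 4.9-fold higher number from compound 1 to compound 4 (0.69 log units; beyond the scatter), is therefore expected. Compound 4 is estimated to give about 15 nM, between 3 nM and 80 nM.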

Compound 4, half-maximal inhibitory concentration: 9.59 nM
Beside the measured number, compound 4's estimate is 1.6-fold (0.19 log units) above it; measured number inside the range.
By their numbers in this assay, from the lowest: compound 1; then compounds 4 and 2 (each within the scatter of the next). At a limit, above all of these: compound 3.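

Going by these compounds alone, compound 4 gives the first reading of this place, opposite the ring nitrogen, since the fluoro of compound 2 and the trifluoromethyl of compound 3 sit elsewhere on the ring. Bromo here brings a 3.1-fold higher number from compound 1 to compound 4 (0.49 log units; beyond the scatter), a modest weakening, so this place takes a halogen with only a limited loss. Nothing shown explains the size of this step.

Going by these compounds, whether fluoro or trifluoromethyl at this same place would give a similar step remains open. So does the effect of an amine or a carboxylic acid here.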